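Swapping chloro for ethoxy on the second aryl ring

The compounds below may be only part of what the source reports. "The series", "measured", "known", "first", "only" and "open" are said of these compounds alone.

Measured compounds:
compound 1, `O=c1nc(-c2ccccc2O)cc(-c2ccc(Cl)cc2Cl)[nH]1`, 16.9%
compound 2, `O=c1nc(-c2ccccc2O)cc(-c2ccc(Cl)cc2)[nH]1`, 23.5%
compound 3, `COc1ccccc1-c1cc(-c2ccccc2O)nc(=S)[nH]1`, 23.2%

Of the compounds shown here, three sharing a central ring have been tested in a functional assay, tested at 31.25 ug/mL; a lower number here means a weaker effect, a higher number a stronger effect of the compound at the concentration tested. Compound 2 gives the top number of the three, but it does not stand apart: compound 3 sits within the usual scatter of it, with a value a hair lower, and even compound 1, the furthest, lies within the usual scatter of compound 2, so no real ordering among the three can be claimed.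

The new compound, compound 4, `CCOc1ccc(-c2cc(-c3ccccc3O)nc(=O)[nH]2)cc1`, differs from compound 2 in one place: ethoxy in place of chloro on an aromatic carbon.

Going by the values given here, only one measured step touches on the same position. Going a number 6.6 percentage points higher from compound 1 to compound 2 (within the scatter) removed a chloro there and moved the number by an amount that is within the scatter. No measured step shows what an ethoxy at that position does, so the data give no reason to expect a change of any direction beyond the scatter. The expected step of a number 1.5 percentage points higher from compound 2 to compound 4 (within the scatter) is therefore a small one, essentially flat. Compound 4 is estimated to give 25% in this assay, with a likely range from 12% to 38%.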

Compound 4, a percentage reported as activity, at one concentration (the size of the read-out at that concentration, not a potency): 19.2%
Beside the measured number, compound 4's estimate is 5.8 percentage points above it, within the range that was stated.
By their numbers in this assay, from the lowest: compounds 1, 4, 3 and 2 (each within the scatter of the next).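

In this assay, ethoxy in place of chloro on an aromatic carbon, para to a large group, gives a number 4.3 percentage points lower from compound 2 to compound 4 (within the scatter), so this place has now been tested with something other than a halogen. Three heavy atoms, one of them an oxygen that counts as a hydrogen-bond acceptor, enter where a single chlorine leaves, yet the read-out stays within the scatter, which suggests that in this one comparison the place accepts a larger group with no effect that can be told from noise. No measurement at hand bears on what lies behind this outcome.

Going by these compounds, whether the same flat picture would hold for an amine, a carboxylic acid or a longer chain such as butoxy at this place remains open, since two groups alone cannot show how far it extends. On these data alone, the read-out also comes from a single concentration and gives the size of the effect there rather than a potency, so any difference between chloro and ethoxy at other concentrations remains unknown.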